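The source may hold more compounds than are shown below. What is called first, only, known or untested is meant among the compounds shown, and "the series" means these compounds.

Measured compounds:
- compound 1 `CCOC(=O)C1=Cc2ccccc2OC1(OCc1cn(CC(=O)Nc2ccccc2F)nn1)C(F)(F)F`: 49900 nM
- compound 2 `O=C(O)C1=Cc2ccccc2OC1(OCc1cc(-c2ccc([N+](=O)[O-])cc2)no1)C(F)(F)F`: > 150000 nM
- compound 3 `CCOC(=O)C1=Cc2ccccc2OC1(OCc1cc(-c2ccc3ccccc3c2)no1)C(F)(F)F`: > 150000 nM

Within the data shown here, in a functional assay on HeLa cells (Homo sapiens) for inhibition, read by MTT assay, with a stated time of 24 h (on this read-out lower numbers stand for stronger inhibition and higher numbers for weaker inhibition), compound 1 gives 49900 nM, and this is the only true number among the three measured compounds. For compound 2 this assay reports only a limit, > 150000 nM. For compound 3 it likewise reports only a limit, > 150000 nM. Among the measured compounds shown here, two of the three values thus sit at the limit of > 150000 nM in this assay, at which 2 of the 3 values shown sit, and compound 1 stands as the one compound with an inhibition that could actually be quantified, although that inhibition is weak.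

Compound 4 `CCOC(=O)C1=Cc2ccccc2OC1(OCc1cn(-c2ccc([N+](=O)[O-])cc2)nn1)C(F)(F)F` has not yet been measured. It differs from compound 1 in a single place: 4-nitrophenyl in place of ((2-fluorophenyl)carbamoyl)methyl on an aromatic nitrogen. For the measured compounds named here, no pair of measured compounds differing in one place exists here, so nothing calibrates this change directly. Compound 2, which also carries 4-nitrophenyl, only reaches a limit in this assay. The step from compound 1 to compound 4 is expected to be a 1.6-fold higher number from compound 1 to compound 4 (0.20 log units; within the scatter), towards weaker inhibition, modest in size and possibly not beyond the usual scatter. Compound 4 is therefore estimated at 80000 nM, with an expected range from 30000 nM to 200000 nM, and a real chance that this assay reports only a limit.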

Compound 4, half-maximal inhibitory concentration: > 150000 nM
Compound 4: a limit, no number; the forecaster's own chance of this, stated with the estimate: 40%; middle value at least 1.8-fold (0.27 log units) from the limit.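

Among these compounds, the change from ((2-fluorophenyl)carbamoyl)methyl to 4-nitrophenyl on this aromatic nitrogen gives the first step that can be read in this assay: an at least 3.0-fold higher number from compound 1 to compound 4 (0.47 log units; beyond the scatter), so the group at this position does affect inhibition, and this change weakens it beyond the scatter. Going by these compounds, compound 4 gives only a limit, > 150000 nM, so the true size of the step remains unknown. Compound 1 is still the only one of the four compounds with a true number, and the others share a single limit: the limit of > 150000 nM in this assay, at which 3 of the 4 values shown sit.

The compounds shown do not reveal which part of the ((2-fluorophenyl)carbamoyl)methyl group matters, the amide or the 2-fluorophenyl ring. On these data alone, it also remains open whether a simple acetamide group, a plain phenyl or a 4-aminophenyl on this nitrogen would give a measurable value.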